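Series notes: methyl for 4-nitrophenyl on the amide carbonyl

The source may hold more compounds than are shown below. What is called first, only, known or untested is meant among the compounds shown, and "the series" means these compounds.

Three compounds of the shared core have readings in a functional assay on MCF7 cells (Homo sapiens) for cytotoxicity, read by MTT assay, with a stated time of 48 h; on this read-out higher numbers stand for weaker inhibition and lower numbers for stronger inhibition. Compound 1 `CNC(=O)CSc1nc2ccc(NC(=O)c3ccccc3OC)cc2s1` gives 23400 nM. Compound 2 `CNC(=O)CSc1nc2ccc(NC(=O)CCl)cc2s1` gives 5000 nM. Compound 3 `CNC(=O)CSc1nc2ccc(NC(=O)c3ccc([N+](=O)[O-])cc3)cc2s1` gives only a limit of the assay, > 100000 nM, and no number. On the readings shown compound 3 thus stands at the weak end, sitting at the limit of > 100000 nM in this assay, at which 1 of the 3 values shown sits. The step of a 4.7-fold lower number from compound 1 to compound 2 (0.67 log units; beyond the scatter) came with chloromethyl in place of 2-methoxyphenyl, the step of an at least 4.2-fold higher number from compound 1 to compound 3 (0.63 log units; beyond the scatter) with 4-nitrophenyl in place of 2-methoxyphenyl, and the step of an at least 20-fold higher number from compound 2 to compound 3 (1.30 log units; beyond the scatter) with 4-nitrophenyl in place of chloromethyl.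

Compound 4 `CNC(=O)CSc1nc2ccc(NC(C)=O)cc2s1` has not yet been measured in this assay. It differs from compound 3 by methyl in place of 4-nitrophenyl on a carbonyl carbon. Among the measured compounds shown here, the step that bears most on this change is the one from compound 2 to compound 3, where a one-carbon group on the carbonyl carbon gave way to 4-nitrophenyl and the number rose by a large margin; the change to compound 4 runs the other way, back to a one-carbon group. Methyl is not chloromethyl, so a full return to the number of compound 2 is not assumed. Compound 4 is therefore expected to show a step of an at least 3.3-fold lower number from compound 3 to compound 4 (0.52 log units; beyond the scatter) from compound 3, to an estimated 30000 nM, with a range from 6000 nM to 150000 nM.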

Compound 4, half-maximal inhibitory concentration: > 100000 nM
Compound 4: only a limit was reported; the forecaster's own chance of this, stated with the estimate: 25%; middle value at least 3.3-fold (0.52 log units) from the limit.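

In this assay compound 4 stands at a limit of the assay and not at a number, as compound 3 does, so the step between them cannot be read, and methyl on the carbonyl carbon brings no measurable reading back: the limit of > 100000 nM in this assay, at which 2 of the 4 values shown sit.

Hydrogen in place of chloro on the saturated chain carbon gives an at least 20-fold higher number from compound 2 to compound 4 (1.30 log units; beyond the scatter), so in this series the reading of 5000-level strength goes with chloromethyl and not with a one-carbon group as such. Methyl in place of 2-methoxyphenyl gives an at least 4.2-fold higher number from compound 1 to compound 4 (0.63 log units; beyond the scatter), so a ring on the carbonyl carbon does not by itself cost the reading, although compound 3, with 4-nitrophenyl, also sits at a limit.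

As far as these compounds go, whether the reading of compound 2 depends on chloro in particular stays open, and bromomethyl, fluoromethyl or aminomethyl on the carbonyl carbon would bear on that. Also open, from the compounds shown here alone, is how far the reading of compound 1 depends on the methoxy group, which a plain phenyl group or 4-methoxyphenyl in the same place would address.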